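The source may hold more compounds than are shown below. What is called first, only, known or untested is meant among the compounds shown, and "the series" means these compounds.

In a functional assay on RS4-11 cells (Homo sapiens) for inhibition, read by CCK-8 assay, with a stated time of 72 h (a lower number here means a stronger inhibitor, a higher number a weaker inhibitor), compound 1 `CC1(C)CCC(CN2CCN(c3ccc(C(=O)NS(=O)(=O)c4ccc(NCC5CCOCC5)c([N+](=O)[O-])c4)c(Oc4cnc5[nH]ccc5c4)c3)CC2)=C(c2ccc(C(F)(F)F)cc2)C1` gives 6.2 nM. Compound 2 `CN1CCC(CNc2ccc(S(=O)(=O)NC(=O)c3ccc(N4CCN(CC5=C(c6ccc(C(F)(F)F)cc6)CC(C)(C)CC5)CC4)cc3Oc3cnc4[nH]ccc4c3)cc2[N+](=O)[O-])C1` gives 8.3 nM, and a 1.3-fold higher number from compound 1 to compound 2 (0.13 log units; within the scatter) separates the two. Compound 3 `CC1(C)CCC(CN2CCN(c3ccc(C(=O)NS(=O)(=O)c4ccc(NC5CCOC5)c([N+](=O)[O-])c4)c(Oc4cnc5[nH]ccc5c4)c3)CC2)=C(c2ccc(C(F)(F)F)cc2)C1` gives 32 nM, the weakest of the three. Compound 4 `CC1(C)CCC(CN2CCN(c3ccc(C(=O)NS(=O)(=O)c4ccc(OCC5CCSCC5)c([N+](=O)[O-])c4)c(Oc4cnc5[nH]ccc5c4)c3)CC2)=C(c2ccc(C(F)(F)F)cc2)C1` differs from it as follows: a group of 8 heavy atoms (6 carbon, 1 oxygen, 1 sulfur; one six-membered non-aromatic ring with 1 hetero atom) in place of a group of 6 heavy atoms (4 carbon, 1 nitrogen, 1 oxygen; one five-membered non-aromatic ring with 1 hetero atom), on an aromatic carbon. The closest evidence comes from the two steps that end at oxolan-3-yl: a 5.2-fold higher number from compound 1 to compound 3 (0.71 log units; beyond the scatter) and a 3.9-fold higher number from compound 2 to compound 3 (0.59 log units; beyond the scatter). Among the measured compounds shown here, compound 4 again carries a six-membered non-aromatic ring, as compound 1 does, but no measured compound has sulfur in this group, so only part of that difference is expected to return. The estimated change, toward a lower number, is a 1.6-fold lower number from compound 3 to compound 4 (0.20 log units; within the scatter). The expected value for compound 4 is 20 nM, with an estimated range from 6 nM to 65 nM.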

Compound 4, half-maximal inhibitory concentration: 15 nM
Compound 4: the middle estimate sits 1.3-fold (0.12 log units) above what was measured; the measured number falls inside the stated range.
By their numbers in this assay, from the lowest: compounds 1, 2 and 4 (each within the scatter of the next, the first and the last beyond it); then compound 3.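

Among the compounds shown here, compound 4 has no hydrogen-bond donor in this group, unlike the earlier compounds, so a donor is not required for activity at this position: the number still falls from the oxolan-3-yl amine (a 2.1-fold lower number from compound 3 to compound 4 (0.33 log units; beyond the scatter)). The comparison with compound 2 shows no real separation (a 1.8-fold higher number from compound 2 to compound 4 (0.26 log units; within the scatter)). Against compound 1, which also has a six-membered ring, the number rises (a 2.4-fold higher number from compound 1 to compound 4 (0.38 log units; beyond the scatter)), so ring size alone does not set the result.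

On these data alone, that step changes both the linking atom and the ring hetero atom, so their separate contributions remain unknown, and a piperidine ring on the same oxygen link would help separate them. No measurement here explains these shifts.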